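The compounds below may be only part of what the source reports. "The series", "measured", "known", "first", "only" and "open" are said of these compounds alone.

Measured so far in a functional assay on HEK293 cells for agonist activity at Toll-like receptor 8 (Homo sapiens), read by reporter gene assay; on this read-out higher numbers stand for an effect only at larger amounts of compound and lower numbers for an effect already at smaller amounts:
compound 1 `Cc1ncc(CO)c(-c2nc3ccccn3c2NC2CCCCC2)c1OCc1ccccc1`: "not active" (no number reported)
compound 2 `CCCCCNc1oc2c(C)ncc(CO)c2c1Nc1cccc([N+](=O)[O-])c1`: 850 nM
compound 3 `Cc1ncc(CO)c2c(Nc3ccccn3)c(N[C@@H](C)c3ccccc3)oc12`: 4270 nM

Compound 3 carries the higher of the two numbers reported in this assay; compound 2 lies beyond the usual scatter from it, and compound 1 gives no number at all. Compound 4 `Cc1ncc(CO)c2c(Nc3ccccn3)c(NC(C)(C)CC(C)(C)C)oc12` keeps the whole of compound 3 apart from one exchange: 1,1,3,3-tetramethylbutyl in place of 1-phenylethyl on a nitrogen on an aromatic ring. Among the compounds with values here, no measured pair shows the effect of such an exchange, so its direction cannot be read from the data. The step is expected to be modest, a 1.4-fold higher number from compound 3 to compound 4 (0.15 log units; within the scatter), with a small drift toward a higher number judged about as likely as no change beyond the scatter. Compound 4 is estimated at 6000 nM in this assay, with a likely range from 1500 nM to 25000 nM.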

Compound 4, half-maximal effective concentration: "not active" (no number reported)
For compound 4 the study gives words and no number; the estimate stays without a comparison.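

Within the data shown here, compound 4 has no number, so no step from compound 3 can be read, and no available evidence bears on this result. The compounds shown leave open how any exchange on this nitrogen shifts the number.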